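A few compounds are considered here, and "the series" means these few. Any claim that something is new, unique, unknown or untested is made for them only; others in the source may bear on it.

Compound 1 `Nc1nc(Nc2ccccc2)sc1C(=O)c1ccc(F)cc1`: 16000 nM
Compound 2 `Nc1nc(Nc2ccc(S(N)(=O)=O)cc2)sc1C(=O)c1ccccc1[N+](=O)[O-]`: 20000 nM

In a functional assay on GC-1 cells (Mus musculus) for cytotoxicity, read by MTT assay, with a stated time of 72 h (a higher number here means a weaker inhibitor, a lower number a stronger inhibitor), compound 2 gives 20000 nM and compound 1 gives 16000 nM on the same read-out. These two numbers lie within the usual scatter of each other, so compound 2 cannot be ranked against compound 1.

Compound 3 `Nc1nc(Nc2ccc(S(N)(=O)=O)cc2)sc1C(=O)c1cccc([N+](=O)[O-])c1` has not yet been measured. It differs from compound 2 in one place, with 3-nitrophenyl in place of 2-nitrophenyl on a carbonyl carbon and the rest of the structure unchanged. Going by the values given here, no pair of measured compounds shows what a change in one place does here, so there is no direct guide to the size of this step. Among the compounds with values here, the only hint is that compound 1 at 16000 nM and compound 2 at 20000 nM sit close together although they differ in more than one place. No shift beyond the scatter is therefore expected, in either direction. The expected change is a 1.3-fold lower number from compound 2 to compound 3 (0.10 log units; within the scatter) and this remains only an estimate. For compound 3 the estimated value is 16000 nM with an expected range from 6000 nM to 40000 nM in this measurement.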

Compound 3, half-maximal inhibitory concentration: 22000 nM
The estimate for compound 3 lay 1.4-fold (0.14 log units) below the measured number, within the range that was stated.
By their numbers in this assay, from the lowest: compounds 1, 2 and 3 (each within the scatter of the next).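

Going by these compounds alone, compound 2 and compound 3 have the same atoms and differ only in carrying 3-nitrophenyl in place of 2-nitrophenyl on a carbonyl carbon, which makes this the first change in one place that can be read here. In this assay, the step is a 1.1-fold higher number from compound 2 to compound 3 (0.04 log units; within the scatter), so this read-out does not separate the two nitrophenyl groups, and moving the nitro group around this ring gives no measurable shift between these two compounds. No measurement is available that bears on why the two compounds read alike.

This single step concerns only where the nitro group sits, so it says nothing about whether the nitro group itself matters to the read-out. A ring carrying an amine or a carboxylic acid in place of the nitro group on this carbonyl carbon would test that, and would show whether any change at this place can move the number beyond the scatter.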